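The compounds below may be only part of what the source reports. "The series", "measured", "known", "first", "only" and "open" are said of these compounds alone.

Measured compounds, in a physicochemical assay for lipophilicity, read by HPLC, measured as octanol-water partition; on this read-out higher numbers stand for higher lipophilicity and lower numbers for lower lipophilicity:
compound 1 `O=C1CCC(=O)N1C[C@H]1CN(c2ccc(-n3cc(-c4ccccn4)cn3)c(F)c2)C(=O)O1` — 1.58
compound 2 `O=C1O[C@@H](Cn2ccnc2)CN1c1ccc(-n2cc(-c3ccccn3)cn2)c(F)c1` — 1.73
compound 3 `O=C1O[C@@H](Cn2ccnn2)CN1c1ccc(-n2cc(-c3ccccn3)cn2)c(F)c1` — 2

Compound 3 gives the highest of the three numbers shown in this assay; its gap to compound 2 is within the scatter, so no order is claimed between those two, while its gap to compound 1 is beyond it. Compound 4 `CCC(=O)NC[C@H]1CN(c2ccc(-n3cc(-c4ccccn4)cn3)c(F)c2)C(=O)O1` differs from compound 3 in one place: propanoylamino in place of 1H-1,2,3-triazol-1-yl on a saturated chain carbon bound to a saturated ring carbon. Among the compounds with values here, no measured step exchanges a five-membered aromatic ring for an open chain with a hydrogen-bond donor. Nearest in kind are a number 0.42 log units higher from compound 1 to compound 3 (beyond the scatter) and a number 0.27 log units higher from compound 2 to compound 3 (within the scatter), which put compound 3 at the top of the set, together with a number 0.15 log units higher from compound 1 to compound 2 (within the scatter). Compound 4 is therefore expected somewhat lower than compound 3, a step of a number 0.30 log units lower from compound 3 to compound 4 (within the scatter) in this assay, near the edge of the scatter. The estimate for compound 4 is 1.7, range 1.3 to 2.1.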

Compound 4, partition coefficient: 2.2
The estimate for compound 4 lay 0.50 log units below the measured number, outside the stated range (above it).
By their numbers in this assay, from the lowest: compounds 1, 2, 3 and 4 (each within the scatter of the next, the first and the last beyond it).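

With a number 0.20 log units higher from compound 3 to compound 4 (within the scatter) no order holds between propanoylamino and 1H-1,2,3-triazol-1-yl on this saturated chain carbon in this assay, so a group with no ring and an amide hydrogen gives a number matching that of the aromatic triazole within the scatter. Against the other two groups the open chain separates, with a number 0.47 log units higher from compound 2 to compound 4 (beyond the scatter) and a number 0.62 log units higher from compound 1 to compound 4 (beyond the scatter). Nothing available explains these steps. Open, on these data alone, is whether a longer acyl chain or an amine on the same chain carbon would shift the number in this assay beyond that of compound 4.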